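A few compounds are considered here, and "the series" means these few. Any claim that something is new, unique, unknown or untested is made for them only; others in the source may bear on it.

Compound 1 `C[C@@H](Nc1c(C(=O)NCc2ccc(F)cc2)nc(Br)c2cccnc12)c1ccccc1` is the starting point of this short series, examined in a functional assay on HCT-116 cells (Homo sapiens) for cytotoxicity, read by MTT assay, with a stated time of 72 h; a higher number here means a weaker inhibitor, a lower number a stronger inhibitor. In this assay compound 1 gives only a limit, > 20000 nM, which is the assay limit described as the limit of > 20000 nM in this assay, at which 1 of the 3 values shown sits, and not a measured number. A related compound 2 `O=C(NCCCNc1c(C(=O)NCc2ccc(F)cc2)nc(Br)c2cccnc12)c1ccccc1`, carrying a longer chain on the same amine, also reaches only a limit in this assay, > 10000 nM, the boundary given as the limit of > 10000 nM in this assay, at which 1 of the 3 values shown sits. Compound 3 `C[C@@H](CO)Nc1nc(C(=O)NCc2ccc(F)cc2)c(O)c2ncccc12`, with a different core, has no result in this assay, recorded as "not determined" (no result reported). Among the compounds with values here, no step between measured compounds can be drawn from these entries, since both numbers are limits.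

Compound 4 `O=C(NCc1ccc(F)cc1)c1nc(Br)c2cccnc2c1NCc1ccccc1` is the next compound to be tested in this assay. It differs from compound 1 by hydrogen in place of methyl on a saturated chain carbon bound to an aromatic carbon and a nitrogen on an aromatic ring. Because compound 1 shows > 20000 nM, a limit rather than a value, the change is expected to bring no step beyond the scatter, that is a number no higher from compound 1 to compound 4 (the limit leaves the size open). Compound 4 is therefore expected to give about 20000 nM, within a range from 5000 nM to 60000 nM, most probably again reported as a limit.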

Compound 4, half-maximal inhibitory concentration: > 20000 nM
Compound 4 was reported as a limit (the forecaster's own chance of this, stated with the estimate: 75%); the middle value sits exactly at the limit.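

In this assay compound 4 also gives only a limit, > 20000 nM. Within the data shown here, compound 1 and compound 2 are limits as well, so no step to compound 4 can be read from either. From the compounds shown here alone, whether swapping 1-phenylethyl for benzyl changes the cytotoxicity at all remains open.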